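The compounds below may be only part of what the source reports. "The series", "measured", "known", "first", "only" and "open" are said of these compounds alone.

Measured in a functional assay on HCT-116 cells (Homo sapiens) for antiproliferative activity, read by MTT assay, with a stated time of 72 h; on this read-out higher numbers stand for weaker inhibition and lower numbers for stronger inhibition:
- Compound 1 `O=C1COc2ccc(-c3cccc(NS(=O)(=O)c4ccc(F)cc4)c3)cc2N1`: > 40000 nM
- Compound 2 `COc1cccc(N2C(=O)COc3ccc(-c4cnc5ccccc5c4)cc32)c1`: 8240 nM
- Compound 3 `COc1ncc(-c2ccc3c(c2)N(c2ccccc2)C(=O)CO3)cc1NS(=O)(=O)c1ccc(F)cc1`: 18800 nM

The entry for compound 1, > 40000 nM, is a limit of the assay and not a number. That leaves two true numbers to compare. Compound 2, at 8240 nM, has the lower of them and so shows the stronger inhibition. Compound 3, at 18800 nM, sits higher, and this gap lies beyond the scatter of repeated measurements.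

Compound 4 `Cc1ccc(N2C(=O)COc3ccc(-c4cnc5ccccc5c4)cc32)cc1` is compound 2 with one group exchanged: it has 4-methylphenyl in place of 3-methoxyphenyl on an amide-type nitrogen in a ring. Both groups contain one six-membered aromatic ring of carbon only, so the exchange alters the substituent on that ring and not the ring itself. Among the compounds with values here, no pair of measured compounds differs at this place alone, so the data offer no direct guide to the effect of this exchange. The starting point is therefore compound 2 at 8240 nM, and no step beyond the scatter is expected in this assay, if anything towards a slightly higher number. The expected step is a 1.2-fold higher number from compound 2 to compound 4 (0.08 log units; within the scatter). For compound 4 the estimated value is 10000 nM, with an expected range from 4000 nM to 25000 nM.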

Compound 4, half-maximal inhibitory concentration: > 40000 nM
Compound 4 ended at the assay's limit; the forecaster's own chance of this, stated with the estimate: 10%; at least 4.0-fold (0.60 log units) between middle value and limit.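

In this assay compound 4 gives > 40000 nM, which is a limit of the assay and not a number. Within the data shown here, putting 4-methylphenyl in place of 3-methoxyphenyl on the amide-type nitrogen gives an at least 4.8-fold higher number from compound 2 to compound 4 (0.68 log units; beyond the scatter), so this position is not indifferent to a change that keeps the six-membered aromatic ring and alters only what that ring carries, a point that the earlier compounds, with no pair differing here alone, could not show. The true size of this loss of inhibition remains unknown, and the printed step is only a lower bound, because compound 4 sits at the top of the measurable range: the limit of > 40000 nM in this assay, at which 2 of the 4 values shown sit.

The two groups differ both in the substituent and in the ring position it holds, so this single exchange cannot tell whether losing the methoxy group or moving to the 4-position matters more, and 3-methylphenyl and 4-methoxyphenyl would be the groups to separate these two changes. On these data alone, it also remains open how this position would respond to a group of a different kind on the same ring, such as an amine or a carboxylic acid.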